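Solubility across a single drawn stereocentre inversion

The source may report more compounds than this note shows. Statements on the series, on what has been measured and on what is new or still open speak of the compounds shown alone.

Going by the values given here, compound 1 `CC(=O)NC[C@H]1CN(c2ccc(OC[C@H]3CN(c4ccccc4)C(=O)O3)c(F)c2)C(=O)O1` and compound 2 `COc1ccc(N2C[C@@H](COc3ccc(N4C[C@H](CNC(C)=O)OC4=O)cc3F)OC2=O)cc1` are the two measured members. In a physicochemical assay for solubility, read by HPLC (a lower number here means a less soluble compound, a higher number a more soluble compound), compound 1 gives 164000 nM. In this assay compound 2 gives 132000 nM, the lowest of the two numbers, with compound 1 as its nearest neighbour at a gap that sits within the scatter, so the two values show no order between them. Compound 3 `COc1ccc(N2C[C@H](COc3ccc(N4C[C@H](CNC(C)=O)OC4=O)cc3F)OC2=O)cc1` is not yet measured. Compound 3 differs from compound 2 as follows: the two compounds have the same atoms and bonds and differ only in configuration as drawn: 1 of 2 stereo elements differ; a stereocentre at a saturated ring carbon is drawn S in compound 2 and R in compound 3. The atoms and bonds stay the same; only the configuration at one saturated ring carbon is redrawn. Among the compounds with values here, no step between measured compounds exists to anchor a change of this kind. For a configurational change alone, no step beyond the scatter is expected in this assay, in either direction. Compound 3 is therefore estimated at 130000 nM, with a range from 65000 nM to 260000 nM. The expected step is a 1.0-fold lower number from compound 2 to compound 3 (0.01 log units; within the scatter), essentially flat.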

Compound 3, solubility: 211000 nM
Compound 3: middle estimate off by 1.6-fold (0.21 log units), on the low side; the range from low to high includes it.
By their numbers in this assay, from the lowest: compounds 2, 1 and 3 (each within the scatter of the next).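

In this assay, going by these compounds alone, redrawing the saturated ring carbon from S to R gives a 1.6-fold higher number from compound 2 to compound 3 (0.20 log units; within the scatter), the first reading of a configurational change, and at this stereocentre the change stays inside the scatter. The comparison isolates this one stereocentre because of a single fact: the fact that compounds 2 and 3 differ only in the configuration as drawn. Methoxy in place of hydrogen on an aromatic carbon gives a 1.3-fold higher number from compound 1 to compound 3 (0.11 log units; within the scatter), so this first reading of that substitution also shows no order between the two compounds.

Open, as far as these compounds go, is whether the other drawn stereo element behaves in the same way when its configuration is redrawn. Also open, from the compounds shown here alone, is whether an amine or a carboxylic acid in place of the methoxy would give a step beyond the scatter, and whether configuration at the saturated ring carbon would then matter.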